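A few compounds are considered here, and "the series" means these few. Any claim that something is new, unique, unknown or untested is made for them only; others in the source may bear on it.

Working notes on the series.

Compound 1, `CCCCc1nc(=O)c(S(=O)(=O)c2ccc(-c3ccnc(NC(=O)C4CC4)c3)cc2)c(O)n1-c1c(OC)cccc1OC`, is the reference point here. Among the measured compounds shown here, in an ADME assay on microsomes from liver (Mus musculus) for metabolic stability, using NADPH, with a stated time of 10 min (a lower number here means that less of the compound is left, a higher number that more of the compound is left), compound 1 gives 72%, the highest of the three numbers measured so far. Compound 2, `CCCCc1[nH]c(=O)c(S(=O)(=O)c2ccc(-c3ccncc3C)cc2)c(O)c1-c1c(OC)cccc1OC`, gives 39%, and compound 3, `CCCCc1[nH]c(=O)c(S(=O)(=O)c2ccc(-c3cccnc3OC)cc2)c(O)c1-c1c(OC)cccc1OC`, gives 24%. For the measured compounds named here, the one step between measured compounds that differ in a single place is a number 15 percentage points lower from compound 2 to compound 3 (beyond the scatter), a change of the aryl group on the same aromatic carbon as in the other two compounds, on a core that differs from the core of compound 1.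

Compound 4, `CCCCc1nc(=O)c(S(=O)(=O)c2ccc(C)cc2)c(O)n1-c1c(OC)cccc1OC`, keeps the core of compound 1 and differs from it only by methyl in place of 2-((cyclopropylcarbonyl)amino)pyridin-4-yl on an aromatic carbon. Going by the values given here, no measured step covers a change of this kind; the step from compound 2 to compound 3 only shows that swapping one aryl group for another at this position moved this assay by a modest amount. Among the compounds with values here, with no closer precedent, the expectation for compound 4 is a step of a number 12 percentage points lower from compound 1 to compound 4 (beyond the scatter), that is a modest move downward or none beyond the scatter. Compound 4 is therefore estimated at 60% in this assay, with a range from 30% to 88%.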

Compound 4, percent of the compound remaining: 80%
Compound 4: middle estimate off by 20 percentage points, on the low side; low and high end bracket the measured number.
By their numbers in this assay, from the lowest: compound 3; then compound 2; then compounds 1 and 4 (each within the scatter of the next).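

On the core of compound 1, methyl in place of the whole 2-((cyclopropylcarbonyl)amino)pyridin-4-yl group gives a number 8 percentage points higher from compound 1 to compound 4 (within the scatter) in this assay, so removing this group, with its 12 heavy atoms and two rings, leaves the read-out unchanged within the scatter. The earlier compounds shown here offered only an exchange of one aryl group for another on a different core, a number 15 percentage points lower from compound 2 to compound 3 (beyond the scatter), and that step said nothing about whether this position needs an aryl group at all; on the core of compound 1, the pair now shows that it does not need one to hold the read-out. Nothing available here accounts for this result.

Left open is how an amine or a carboxylic acid on this aromatic carbon would read in this assay, and whether methyl would read the same on the core shared by compound 2 and compound 3. Also open, from the compounds shown here alone, is what removing the three-membered ring alone would do, as compound 4 loses both rings of the departing group in one change.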